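The compounds below may be only part of what the source reports. "The series", "measured", "known", "first", "only" and "open" are said of these compounds alone.

Compound 2 `COc1cc(-c2cc(/C=C/C(=O)c3ccc(N)cc3)[nH]n2)cc(OC)c1OC` gives 90% in a functional assay on M14 cells (Homo sapiens) for cytotoxicity, read by sulforhodamine B assay, with a stated time of 48 h, tested at 1 uM; a higher number here means a weaker effect of the compound at the concentration tested, a lower number a stronger effect. Its number is the lowest of the three, but compound 3 `COc1ccc(C(=O)/C=C/c2cc(-c3cc(OC)c(OC)c(OC)c3)n[nH]2)cc1OC` stands within the scatter of it with 94%, and only compound 1 `COc1ccc(-c2cc(/C=C/C(=O)c3ccc(N)cc3)[nH]n2)cc1`, which gives 105%, lies beyond the scatter of it. Compound 4 `COc1ccc(-c2cc(/C=C/C(=O)c3ccc(N)cc3)[nH]n2)cc1OC` differs from compound 2 in one place: hydrogen in place of methoxy on an aromatic carbon. Among the measured compounds shown here, no measured step removes a methoxy group; the one step at hand, a number 4 percentage points higher from compound 2 to compound 3 (within the scatter), alters a different part of the molecule and stays within the scatter. For the measured compounds named here, compound 1 and compound 2 differ in more than one place, so their gap shows only that compound 1, with fewer methoxy groups, gives the higher number. Compound 4 is therefore expected to give a number a number 6 percentage points higher from compound 2 to compound 4 (within the scatter), not clearly beyond the scatter. The estimate for compound 4 is 96%, within 82% to 110%.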

Compound 4, a percentage reported as activity, at one concentration (the size of the read-out at that concentration, not a potency): 101%
Compound 4: middle estimate off by 5 percentage points, on the low side; the range from low to high includes it.
By their numbers in this assay, from the lowest: compounds 2, 3, 4 and 1 (each within the scatter of the next, the first and the last beyond it).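

In this assay, among the compounds shown here, this is the first measured step that removes a methoxy group from this ring, and with hydrogen in place of methoxy at the position meta to a large group it gives a number 11 percentage points higher from compound 2 to compound 4 (beyond the scatter) as a modest change. The other methoxy change on this ring, methoxy in place of hydrogen, gives a number 4 percentage points lower from compound 1 to compound 4 (within the scatter) by comparison. For the compounds shown here, of these two changes, only the one at this position moves the number beyond the scatter.

Nothing available explains this difference. From the compounds shown here alone, whether a hydroxy group or a chlorine atom at this position would behave like methoxy or like hydrogen remains open.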